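The source may hold more compounds than are shown below. What is called first, only, known or untested is meant among the compounds shown, and "the series" means these compounds.

Compound 1 `Cc1cn([C@H]2C[C@@H](C#N)[C@@H](CO)O2)c(=O)[nH]c1=O` is a nucleoside-like molecule in which the sugar ring carries a nitrile group and a hydroxymethyl group. In an ADME assay on HeLa cells (Homo sapiens) for cytotoxicity (a lower number here means that less compound is tolerated, a higher number that more compound is tolerated), compound 1 gives > 400 ug/mL, which is a limit of the assay rather than a measured number: the cells tolerated every concentration tested. This sits at the limit of > 400 ug/mL in this assay, at which 1 of the 2 values shown sits. Compound 2 `Cc1cn(C2CC(C#N)C(CO[Si](C)(C)C(C)(C)C)O2)c(=O)[nH]c1=O` carries the same core with a bulky silyl protecting group on the hydroxymethyl oxygen and is drawn without defined configuration; in this assay compound 2 gives 100 ug/mL, a number inside the range of the assay.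

Compound 3 `Cc1cn([C@H]2C[C@H](C#N)[C@@H](CO)O2)c(=O)[nH]c1=O` is the next compound to be examined. Its change from compound 1 is this: the two compounds have the same atoms and bonds and differ only in configuration as drawn: 1 of 3 stereo elements differ; a stereocentre at a saturated ring carbon is drawn S in compound 1 and R in compound 3. No atom is added or removed; only the spatial arrangement at one ring carbon is reversed.

Within the data shown here, with no measured pair of compounds differing only in configuration, the size of this step is uncertain. Since compound 1 reports only a limit > 400 ug/mL, the expectation for compound 3 is a value that again reaches that limit, with a step of a number no higher from compound 1 to compound 3 (the limit leaves the size open) expected to be nothing beyond the scatter. The estimate for compound 3 is therefore 400 ug/mL, within a range from 200 ug/mL to 800 ug/mL.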

Compound 3, minimum cytotoxic concentration: 200 ug/mL
Beside the measured number, compound 3's estimate is 2.0-fold (0.30 log units) above it; measured number inside the range.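

In this assay compound 3, which keeps the free hydroxymethyl group and the nitrile of the shared core, gives 200 ug/mL, a number inside the range of the assay. For compound 1, the value > 400 ug/mL is a limit of the assay and not a number. Reversing the configuration at one saturated ring carbon therefore gives an at least 2.0-fold lower number from compound 1 to compound 3 (0.30 log units; that floor lies within the scatter), so a real effect of the configuration at this position is not established, although the true step could be larger, and any such effect could have only one source: the fact that compounds 1 and 3 differ only in the configuration as drawn.

The compounds shown leave open how large the step truly is, since only a floor can be read from a limit, and whether the other two stereocentres of the core matter in the same way. They also leave open how the tolerated concentration would respond if the nitrile at this ring carbon gave way to an amine or a carboxylic acid, in either configuration.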